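The compounds below may be only part of what the source reports. "The series", "measured", "known", "first", "only" and "open" are said of these compounds alone.

Of the compounds shown here, three on one shared core have numbers so far in a functional assay on PC-3 cells (Homo sapiens) for antiproliferative activity, read by MTT assay, with a stated time of 96 h; on this read-out higher numbers stand for weaker inhibition and lower numbers for stronger inhibition. Compound 1 `FC(F)(F)Oc1cccc(Nc2nnnc3ccc(N4CCC(N5CCCCC5)CC4)nc23)c1` gives 5580 nM, compound 2 `CC(C)N1CCN(c2ccc3nnnc(Nc4cccc(OC(F)(F)F)c4)c3n2)CC1` gives 13800 nM, and compound 3 `FC(F)(F)Oc1cccc(Nc2nnnc3ccc(Cl)nc23)c1` gives 5990 nM. Compound 3 therefore lies within the scatter of compound 1 and beyond the scatter on the stronger side of compound 2.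

The change under consideration leads from compound 3 to compound 4 `FC(F)(F)Oc1cccc(Nc2nnnc3ccc(N4CCC(N5CCCC5)CC4)nc23)c1`: 4-(pyrrolidin-1-yl)piperidin-1-yl in place of chloro on an aromatic carbon. The new group, 4-(pyrrolidin-1-yl)piperidin-1-yl, takes the place of chloro on an aromatic carbon, next to the ring nitrogen.

For the measured compounds named here, one measured step bears on this, and it runs the opposite way: a 2.3-fold lower number from compound 2 to compound 3 (0.36 log units; beyond the scatter). That step is modest and has chloro entering in place of 4-isopropylpiperazin-1-yl. Read backwards, it hints that losing chloro could raise the number. Compound 1 goes against that hint: it also lacks chloro, carries the group closest in structure to the entering one, and its value of 5580 nM sits within the scatter of compound 3.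

No step beyond the scatter is therefore expected in this assay, with only a slight lean towards weaker inhibition. The expected change is a 1.1-fold higher number from compound 3 to compound 4 (0.04 log units; within the scatter). Compound 4 is estimated at 6500 nM, with an expected range of 2800 nM to 14000 nM.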

Compound 4, half-maximal inhibitory concentration: 8160 nM
The estimate for compound 4 lay 1.3-fold (0.10 log units) below the measured number; measured number inside the range.
By their numbers in this assay, from the lowest: compounds 1, 3, 4 and 2 (each within the scatter of the next, the first and the last beyond it).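

In this assay the step of a 1.4-fold higher number from compound 3 to compound 4 (0.13 log units; within the scatter) shows that at this position, on an aromatic carbon next to the ring nitrogen, replacing a lone chloro with the much larger 4-(pyrrolidin-1-yl)piperidin-1-yl, with its five- and six-membered non-aromatic rings, gives no change beyond the scatter. The series also now has a direct comparison of the terminal ring, and a 1.5-fold higher number from compound 1 to compound 4 (0.17 log units; within the scatter) places pyrrolidin-1-yl and piperidin-1-yl on the saturated ring carbon within the scatter of each other in this assay. The step of a 1.7-fold lower number from compound 2 to compound 4 (0.23 log units; within the scatter) is likewise within the scatter, so 4-(pyrrolidin-1-yl)piperidin-1-yl cannot be told apart from 4-isopropylpiperazin-1-yl here, even though the chloro compound is separated from compound 2 by a 2.3-fold lower number from compound 2 to compound 3 (0.36 log units; beyond the scatter) and the modest gap seen there does not extend to every replacement at this position.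

The compounds shown leave open how a morpholine ring or an open-chain amine such as dimethylamino would read at this position, and whether any group there can move the number clearly beyond the scatter of the chloro compound. No measurement at hand accounts for these values.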